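This account rests on a few compounds, and the source may have more. Where it says the series, first, only, none or still open, it means among the compounds named here.

Measured so far in a functional assay on NCI-H460 cells (Homo sapiens) for inhibition, read by MTT assay, with a stated time of 72 h; a lower number here means a stronger inhibitor, a higher number a weaker inhibitor:

compound 1, `COc1cc2c(Oc3ccc(NC(=O)c4nn(-c5ccccc5C)c(=O)cc4C)cc3F)ccnc2cc1OCCCN1CCCC1`, gives 1590 nM
compound 2, `COc1cc2c(Oc3ccc(NC(=O)c4nn(-c5ccccc5C)c(=O)cc4C)cc3F)ccnc2cc1OCCCN1CCN(C)CC1`, gives 3420 nM
compound 3, `COc1cc2c(Oc3ccc(NC(=O)c4nn(-c5ccc(F)c(F)c5)c(=O)cc4C)cc3F)ccnc2cc1OCCCN1CCCC1`, gives 170 nM

Compounds 1 and 2 share a core and differ in a single place: 4-methylpiperazin-1-yl in place of pyrrolidin-1-yl on a saturated chain carbon, three bonds along the chain from an oxygen on an aromatic ring. That change brought a 2.2-fold higher number from compound 1 to compound 2 (0.33 log units; beyond the scatter). Compound 3 differs from compound 1 in a different place: 3,4-difluorophenyl in place of 2-methylphenyl on an aromatic nitrogen. That change brought a 9.4-fold lower number from compound 1 to compound 3 (0.97 log units; beyond the scatter), and compound 3 stands with the lowest number of the three, with its steps to compounds 1 and 2 both beyond the scatter.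

Compound 4, `COc1cc2c(Oc3ccc(NC(=O)c4nn(-c5ccc(F)c(F)c5)c(=O)cc4C)cc3F)ccnc2cc1OCCCN1CCN(C)CC1`, has not yet been measured in this assay. It differs from compound 3 by 4-methylpiperazin-1-yl in place of pyrrolidin-1-yl on a saturated chain carbon, three bonds along the chain from an oxygen on an aromatic ring. The place where this change is made is the same, word for word, as in the change from compound 1 to compound 2, so it is the same change, now made on the core of compound 3 instead of the core of compound 1; how those two cores differ has already been described. Among the compounds with values here, only one earlier example of the change is at hand, so the expectation for compound 4 rests on that single example alone.

For compound 4 the expected step is a 2.2-fold higher number from compound 3 to compound 4 (0.34 log units; beyond the scatter), set beside the earlier 2.2-fold higher number from compound 1 to compound 2 (0.33 log units; beyond the scatter), and it is expected to be of about that same size. The estimate for compound 4 in this assay is 370 nM, with a likely range from 190 nM to 750 nM.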

Compound 4, half-maximal inhibitory concentration: 190 nM
Compound 4: middle estimate off by 1.9-fold (0.29 log units), on the high side, and the stated range covers the measured number.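

In this assay, putting 4-methylpiperazin-1-yl in place of pyrrolidin-1-yl on the core of compound 3 gave a 1.1-fold higher number from compound 3 to compound 4 (0.05 log units; within the scatter), and the gap between this step and the earlier one on the core of compound 1 is no larger than repeat measurements could produce: the same change on two cores in this assay, a 2.2-fold higher number (0.33 log units; beyond the scatter) from compound 1 to compound 2 and a 1.1-fold higher number (0.05 log units; within the scatter) from compound 3 to compound 4, 1.9-fold (0.28 log units) apart, within the scatter of two such steps. The other change, 3,4-difluorophenyl in place of 2-methylphenyl on an aromatic nitrogen, gave an 18-fold lower number from compound 2 to compound 4 (1.26 log units; beyond the scatter), and it also carried over between the two cores, staying large on both: the same change on two cores in this assay, a 9.4-fold lower number (0.97 log units; beyond the scatter) from compound 1 to compound 3 and an 18-fold lower number (1.26 log units; beyond the scatter) from compound 2 to compound 4, 1.9-fold (0.28 log units) apart, within the scatter of two such steps. This shows that, across these four compounds, each change behaved about the same on either core, but it does not fix the true size of the amine step, which is beyond the scatter on one core and within it on the other, and two cores are too few to show that the pattern holds across the wider series.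

The compounds shown leave open how other amines at the end of the chain, such as morpholine or dimethylamine, or a longer chain than the 3-(pyrrolidin-1-yl)propyl group, would behave. They also leave open whether other groups on the phenyl ring, such as a single fluorine or a chlorine, would match the 3,4-difluorophenyl result.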